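Capping the Phenol Hydroxyl: Expected Shift in Cell Toxicity

This account rests on a few compounds, and the source may have more. Where it says the series, first, only, none or still open, it means among the compounds named here.

Compound 1 `Cc1nc(C)c(C(=O)Oc2ccc(/C=C/C(=O)O)cc2O)nc1C` gives 285% in a functional assay on EA.hy 926 cells (Homo sapiens) for cytotoxicity, read by MTT assay, with stated times of 24 h and 12 h, tested at 50 uM; on this read-out lower numbers stand for a weaker effect and higher numbers for a stronger effect at the one concentration tested.
Compound 2 `CCOC(=O)/C=C/c1ccc(OC(=O)c2nc(C)c(C)nc2C)c(O)c1` gives 211% in this assay.
Compound 3 `Cc1nc(C)c(C(=O)Oc2ccc(Cl)cc2/C=C/C(=O)O)nc1C` gives 23.7% in this assay.

Compound 2 stands second highest of the three; compound 1 is higher and compound 3 is much lower, both gaps beyond the scatter. Compound 4 `CCOC(=O)/C=C/c1ccc(OC(=O)c2nc(C)c(C)nc2C)c(OC)c1` differs from compound 2 in one place: methyl in place of hydrogen on an oxygen on an aromatic ring. Within the data shown here, no measured step tests this same change. Among the measured compounds shown here, the only measured step, a number 74 percentage points lower from compound 1 to compound 2 (beyond the scatter), concerns a different oxygen and therefore only shows that single small changes on this core can move the read-out a long way. With no direct guide, a moderate downward step is expected, a number 41 percentage points lower from compound 2 to compound 4 (beyond the scatter), with a wide range. Compound 4 is estimated at 170%, between 90% and 240%.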

Compound 4, a percentage reported as activity, at one concentration (the size of the read-out at that concentration, not a potency): 69.7%
Estimate against measurement, compound 4: 100.3 percentage points above, outside the stated range (below it).
By their numbers in this assay, from the lowest: compound 3; then compound 4; then compound 2; then compound 1.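

Capping the hydroxy group on the aromatic ring matters a great deal in this assay: hydroxy to methoxy adds only one carbon, yet it gives a number 141.3 percentage points lower from compound 2 to compound 4 (beyond the scatter). This first measured change at this oxygen moves the read-out further than the ethyl change at the other oxygen, a number 74 percentage points lower from compound 1 to compound 2 (beyond the scatter). Nothing available here explains the size of this drop.

As far as these compounds go, whether a longer chain such as ethoxy, or an amine, at this place would behave like methoxy stays open. So does whether the same methyl change would lower the read-out of compound 1, which keeps its carboxylic acid.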